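A few compounds are considered here, and "the series" means these few. Any claim that something is new, unique, unknown or untested is made for them only; others in the source may bear on it.

Measured compounds:
- compound 1, `O=C1O[C@H]([C@@H](O)Cn2cc(CNS(=O)(=O)c3ccc(Cl)cc3F)nn2)C(OCc2ccccc2)=C1OCc1ccccc1`, in a functional assay on HepG2 cells (Homo sapiens) for antiproliferative activity, read by MTT assay, with a stated time of 72 h (a higher number here means a weaker inhibitor, a lower number a stronger inhibitor), gives 25500 nM
- compound 2, `C[Si](C)(C)c1cn(C[C@H](O)[C@H]2OC(=O)C(OCc3ccccc3)=C2OCc2ccccc2)nn1`, in this assay gives 24100 nM
- compound 3, `O=C1O[C@H]([C@@H](O)Cn2cc(CCO)nn2)C(OCc2ccccc2)=C1OCc1ccccc1`, in this assay gives 68100 nM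

Compound 3 stands highest of the three numbers, that is, it is the weakest inhibitor here; its steps to compound 1 and to compound 2 are both beyond the scatter. The unmeasured compound 4, `O=C1O[C@H]([C@@H](O)Cn2cc(-c3ccc(Br)cc3)nn2)C(OCc2ccccc2)=C1OCc1ccccc1`, differs from compound 3 in one place: 4-bromophenyl in place of 2-hydroxyethyl on an aromatic carbon. Within the data shown here, two measured steps bear on this position, since both also replace the 2-hydroxyethyl of compound 3 with a larger group without a hydrogen-bond donor: a 2.7-fold higher number from compound 1 to compound 3 (0.43 log units; beyond the scatter) and a 2.8-fold higher number from compound 2 to compound 3 (0.45 log units; beyond the scatter). Read in the opposite direction, both say that taking away the 2-hydroxyethyl and putting a larger group in its place lowers the number by a modest amount. The 4-bromophenyl is larger again and carries an aromatic ring, so a step of similar or somewhat greater size toward a lower number is expected, a 7.6-fold lower number from compound 3 to compound 4 (0.88 log units; beyond the scatter). Compound 4 is therefore estimated at 9000 nM, within a range from 3500 nM to 25000 nM.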

Compound 4, half-maximal inhibitory concentration: 5070 nM
Beside the measured number, compound 4's estimate is 1.8-fold (0.25 log units) above it, and the stated range covers the measured number.
By their numbers in this assay, from the lowest: compound 4; then compounds 2 and 1 (each within the scatter of the next); then compound 3.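

In this assay, among these compounds, the earlier compounds showed only modest steps at this carbon of the five-membered aromatic ring with 3 nitrogen, whereas 4-bromophenyl in place of 2-hydroxyethyl gives a 13-fold lower number from compound 3 to compound 4 (1.13 log units; beyond the scatter), a large step and the first with an aromatic ring directly on this carbon. The change also holds against a group with no hydrogen-bond donor: the step of a 4.8-fold lower number from compound 2 to compound 4 (0.68 log units; beyond the scatter) replaces a group without a ring, so the earlier loss of the 2-hydroxyethyl does not account for all of the drop in the number. Nothing available explains why this change lowers the number.

The compounds shown leave open whether the bromine or the phenyl ring matters more, which a plain phenyl or a 4-chlorophenyl group on this carbon could separate. They also leave open how a benzyl group, with a carbon between the two rings, would compare.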